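The source may report more compounds than this note shows. Statements on the series, on what has been measured and on what is new or still open speak of the compounds shown alone.

Measured in a functional assay on MCF7 cells (Homo sapiens) for antiproliferative activity, read by MTT assay, with a stated time of 24 h; on this read-out higher numbers stand for weaker inhibition and lower numbers for stronger inhibition:

- Compound 1 `COc1ccc(-c2noc(-c3ccccc3)n2)cc1OC1CCCC1`: > 1000000 nM, a limit
- Compound 2 `COc1ccc(-c2noc(C3CCNCC3)n2)cc1OC1CCCC1`: 3880 nM
- Compound 3 `COc1cc(-c2noc(-c3ccncc3)n2)ccc1OCc1ccccc1`: > 1000000 nM, a limit

Among the measured compounds shown here, compound 2 holds the only actual number of the three, as the other two compounds reach only (the limit of > 1000000 nM in this assay, at which 2 of the 3 values shown sit). Compound 4 `COc1ccc(-c2noc(-c3ccc(Cl)cc3)n2)cc1OC1CCCC1` has not yet been measured. It carries 4-chlorophenyl in place of piperidin-4-yl on an aromatic carbon. For the measured compounds named here, the one measured step that bears on this change is an at least 250-fold lower number from compound 1 to compound 2 (2.41 log units; beyond the scatter), which also exchanges piperidin-4-yl and an aromatic ring, but in the opposite direction. Compound 4 thus returns to an aromatic ring, so a large move to a higher number is expected: a 100-fold higher number from compound 2 to compound 4 (2.01 log units; beyond the scatter). Compound 4 is expected at about 400000 nM, with an estimated range of 40000 nM to 1000000 nM.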

Compound 4, half-maximal inhibitory concentration: 174000 nM
Compound 4: the middle estimate sits 2.3-fold (0.36 log units) above what was measured, and the stated range covers the measured number.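

In this assay, chloro in place of hydrogen on the phenyl group gives an at least 5.7-fold lower number from compound 1 to compound 4 (0.75 log units; beyond the scatter) and so brings an aromatic ring at this place off the limit. Piperidin-4-yl still keeps a large lead over 4-chlorophenyl, as shown by a 45-fold higher number from compound 2 to compound 4 (1.65 log units; beyond the scatter) and this on the same core. The step from compound 1 starts from a limit and not from a number: the limit of > 1000000 nM in this assay, at which 2 of the 4 values shown sit.

As far as these compounds go, what a cyclohexyl group or an open-chain amine would give at this carbon stays open. So does whether fluoro or methoxy on the phenyl group would act as chloro does.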